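Replacing Methoxyphenyl with Difluorophenyl in a Cytotoxicity Series

The source may report more compounds than this note shows. Statements on the series, on what has been measured and on what is new or still open speak of the compounds shown alone.

The three measured compounds share one core. In a functional assay on PC-3 cells (Homo sapiens) for cytotoxicity, read by MTT assay, with a stated time of 72 h (on this read-out lower numbers stand for stronger inhibition and higher numbers for weaker inhibition), compound 3 `COc1ccc(-c2ccc(C(=O)Nc3ccc(Oc4ccnc5[nH]ccc45)c(F)c3)nc2)cc1` gives 650 nM, the lowest of the two numbers recorded. Compound 2 `COc1ccc(-c2ccnc(C(=O)Nc3ccc(Oc4ccnc5[nH]ccc45)cc3)c2)cc1` gives 9620 nM in this assay. Compound 1 `COc1ccc(-c2ccc(C(=O)Nc3ccc(Oc4ccnc5[nH]ccc45)cc3)nc2)cc1` gives > 10000 nM in this assay, which is a limit of > 10000 nM in this assay, at which 1 of the 3 values shown sits, and not a number. Among the compounds with values here, the single one-place step measured, an at least 15-fold lower number from compound 1 to compound 3 (1.18 log units; beyond the scatter), is large and beyond the scatter.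

Compound 4 `O=C(Nc1ccc(Oc2ccnc3[nH]ccc23)c(F)c1)c1ccc(-c2ccc(F)cc2F)cn1` differs from compound 3 by 2,4-difluorophenyl in place of 4-methoxyphenyl on an aromatic carbon. Within the data shown here, no measured step touches this part of the molecule; the only recorded step concerns a fluorine added on another ring, so it gives no direct guide to the present change. With the data pointing in neither direction, a step of no more than the usual scatter is expected, a 1.2-fold higher number from compound 3 to compound 4 (0.09 log units; within the scatter). Compound 4 is therefore estimated at 800 nM in this assay, with a range from 250 nM to 2500 nM.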

Compound 4, half-maximal inhibitory concentration: 4720 nM
The estimate for compound 4 lay 5.9-fold (0.77 log units) below the measured number; the measured number lies above the stated range.
By their numbers in this assay, from the lowest: compound 3; then compound 4; then compound 2. At a limit, above all of these: compound 1.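

In this assay, within the data shown here, 2,4-difluorophenyl in place of 4-methoxyphenyl gives a 7.3-fold higher number from compound 3 to compound 4 (0.86 log units; beyond the scatter) and is the first measured step at this position, two atoms from the ring nitrogen and para to a large group. It shows that the number depends on the group carried here, even with the fluoro of compound 3 kept in compound 4, whereas the earlier step, an at least 15-fold lower number from compound 1 to compound 3 (1.18 log units; beyond the scatter) and resting on a limit, concerned another ring and ran towards a lower number. Nothing measured here accounts for this step.

Going by these compounds, whether the higher number follows from losing the methoxy group or from gaining the two fluorines stays open. So does how a phenyl ring carrying an amine or a carboxylic acid at this position would read in this assay against compound 3.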